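Swapping the amide amine for a tetrahydroquinoline

A few compounds are considered here, and "the series" means these few. Any claim that something is new, unique, unknown or untested is made for them only; others in the source may bear on it.

Three measured compounds share one core and differ only in the amine joined to the carbonyl carbon. Compound 1 `CC(C(=O)N1C[C@H]2CCC[C@H]2C1)N1CCN(S(=O)(=O)c2ccc(C(C)(C)C)cc2)CC1` carries a fused bicyclic amine there, compound 2 `CC(C(=O)N1CCC2(CC1)CC2)N1CCN(S(=O)(=O)c2ccc(C(C)(C)C)cc2)CC1` a spiro amine, and compound 3 `CC(C(=O)N1CCN(C)CC1)N1CCN(S(=O)(=O)c2ccc(C(C)(C)C)cc2)CC1` a 4-methylpiperazin-1-yl group. In an ADME assay on HepG2 cells (Homo sapiens) for inhibition, with a stated time of 48 h (a higher number here means that more compound is needed for the effect, a lower number that less compound is needed), compound 1 gives only a limit, > 40000 nM. Compound 2 likewise gives only a limit in this assay, > 40000 nM. Compound 3 also reaches only a limit, > 40000 nM. All three values rest at the limit of > 40000 nM in this assay, at which 3 of the 3 values shown sit. Since no number exists for any of them, the steps between them cannot be read: a step that the two limits leave unreadable from compound 1 to compound 2, a step that the two limits leave unreadable from compound 1 to compound 3 and a step that the two limits leave unreadable from compound 2 to compound 3 all stay unreadable in size and direction. Compound 3 therefore stands exactly where the other two stand, at a limit rather than at a number.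

Compound 4 `CC(C(=O)N1CCCc2ccccc21)N1CCN(S(=O)(=O)c2ccc(C(C)(C)C)cc2)CC1` keeps the core and puts (1,2,3,4-tetrahydroquinolin-1-yl in place of 4-methylpiperazin-1-yl on a carbonyl carbon). Among the measured compounds shown here, none of the measured steps offers a readable size, so the step from compound 3 to compound 4 is expected to stay within the scatter, a number no higher from compound 3 to compound 4 (the limit leaves the size open). Compound 4 is accordingly expected to give about 40000 nM, estimated between 15000 nM and 100000 nM, most likely once more reported only as a limit.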

Compound 4, half-maximal effective concentration: > 40000 nM
Compound 4 was reported as a limit; the forecaster's own chance of this, stated with the estimate: 75%; the middle value sits exactly at the limit.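

In this assay compound 4 gives only a limit, > 40000 nM. Its steps from compound 1, compound 2 and compound 3 therefore cannot be read in size or direction, and all four compounds rest together: the limit of > 40000 nM in this assay, at which 4 of the 4 values shown sit.

The compounds shown leave open whether changing the amine on the carbonyl carbon makes any difference in this assay.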